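Aryl amine variation on a shared core: cytotoxicity notes

The source may report more compounds than this note shows. Statements on the series, on what has been measured and on what is new or still open speak of the compounds shown alone.

Measured compounds:
compound 1 `FC(F)(F)c1ccc(CSc2nc(Nc3ccccc3Cl)c3ccccc3n2)cc1`: > 50000 nM in a functional assay on HGC-27 cells (Homo sapiens) for cytotoxicity, read by MTT assay, with a stated time of 72 h; on this read-out higher numbers stand for weaker inhibition and lower numbers for stronger inhibition
compound 2 `FC(F)(F)c1ccc(CSc2nc(Nc3cccc(C(F)(F)F)c3)c3ccccc3n2)cc1`: 11700 nM
compound 3 `COc1ccc(Nc2nc(SCc3ccc(C(F)(F)F)cc3)nc3ccccc23)cc1`: 23500 nM

Compound 1 gives only a limit in this assay, not a number, as it sits at the limit of > 50000 nM in this assay, at which 1 of the 3 values shown sits. Compound 4 `COc1cc(Nc2nc(SCc3ccc(C(F)(F)F)cc3)nc3ccccc23)cc(OC)c1` keeps the shared core of compound 1 and changes one group: 3,5-dimethoxyphenyl in place of 2-chlorophenyl on a nitrogen on an aromatic ring.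

Two measured steps leave the same 2-chlorophenyl group from compound 1 and so bear on this change. One is an at least 4.2-fold lower number from compound 1 to compound 2 (0.63 log units; beyond the scatter), the other at least 2.1-fold lower number from compound 1 to compound 3 (0.32 log units; beyond the scatter). Both steps are read against a limit, so they give only a floor to the gain. Between the two replacement groups the difference is a 2.0-fold higher number from compound 2 to compound 3 (0.30 log units; within the scatter), so the two measured values do not separate from each other. Of the measured compounds, compound 3 is the closer analogue of compound 4, sharing a methoxy substituent on the same ring.

On this basis a downward step from compound 1 is expected, of at least modest size. Compound 4 is expected to fall near 20000 nM, within 8000 nM to 50000 nM, which would mean an at least 2.5-fold lower number from compound 1 to compound 4 (0.39 log units; beyond the scatter).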

Compound 4, half-maximal inhibitory concentration: > 50000 nM
Compound 4: a limit, no number (the forecaster's own chance of this, stated with the estimate: 25%); middle value at least 2.5-fold (0.39 log units) from the limit.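

In this assay, 3,5-dimethoxyphenyl in place of 4-methoxyphenyl gives an at least 2.1-fold higher number from compound 3 to compound 4 (0.32 log units; beyond the scatter), so a methoxy group on this ring does not by itself preserve the measurable value of compound 3. The same group in place of 3-(trifluoromethyl)phenyl gives an at least 4.2-fold higher number from compound 2 to compound 4 (0.63 log units; beyond the scatter), which shows that, among the groups compared here, a measurable value at this place on a nitrogen on an aromatic ring depends on which substituted phenyl is attached and is not gained simply by leaving 2-chlorophenyl. The step from compound 1 to compound 4 cannot be read, so these two groups cannot be ordered, and the limit now applies to two different aryl groups: the limit of > 50000 nM in this assay, at which 2 of the 4 values shown sit.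

Going by these compounds, it remains open how far the true values of compound 1 and compound 4 lie from this limit, and whether they differ at all. On these data alone, it is also open whether a pyridine ring in place of the phenyl, or an amine or a carboxylic acid on that ring, would give a value that separates from those of compound 2 and compound 3.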